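Same Side-Chain Swap, Applied to Two Different Cores

The source may report more compounds than this note shows. Statements on the series, on what has been measured and on what is new or still open speak of the compounds shown alone.

Compound 1 `COCCCN1CCC(O)(CNC(=O)c2nc(C(C)C)n3ccccc23)CC1` gives 316 nM in a functional assay on CHO cells for agonist activity at 5-hydroxytryptamine receptor 4 (Homo sapiens), read by a luciferase reporter and cAMP accumulation, with a stated time of 4 h; on this read-out lower numbers stand for an effect already at smaller amounts and higher numbers for an effect only at larger amounts of compound.
Compound 2 `CC(C)c1nc(C(=O)NCC2(O)CCN(CC(C)(C)O)CC2)c2ccccn12` gives 72.3 nM in this assay.
Compound 3 `COCCCN1CC2C(C1)C2NC(=O)c1nc(C(C)C)n2ccccc12` gives only a limit of this assay, > 10000 nM.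

The change from compound 1 to compound 2 is 1-hydroxy-1-methylethyl in place of 2-methoxyethyl on a saturated chain carbon bound to an amine nitrogen in a ring; it produced a 4.4-fold lower number from compound 1 to compound 2 (0.64 log units; beyond the scatter). Compound 4 `CC(C)c1nc(C(=O)NC2C3CN(CC(C)(C)O)CC32)c2ccccn12` differs from compound 3 by 1-hydroxy-1-methylethyl in place of 2-methoxyethyl on a saturated chain carbon bound to an amine nitrogen in a ring, the same change at the same kind of place. How the core of compound 3 differs from the core of compound 1 is not broken down here.

Compound 3 sits at the limit of > 10000 nM in this assay, at which 1 of the 3 values shown sits, so any gain must start from that limit. By analogy with the measured pair, compound 4 is expected to show a step of about an at least 1.2-fold lower number from compound 3 to compound 4 (0.09 log units; that floor lies within the scatter). Compound 4 is therefore estimated at 8000 nM, roughly between 2000 nM and 30000 nM, with a real chance that this assay again reports only a limit.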

Compound 4, half-maximal effective concentration: > 10000 nM
Compound 4 was reported as a limit (the forecaster's own chance of this, stated with the estimate: 55%); middle value at least 1.2-fold (0.09 log units) from the limit.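

Going by these compounds alone, compound 3 and compound 4 both stand as limits, so no step between them can be read: the limit of > 10000 nM in this assay, at which 2 of the 4 values shown sit.

As far as these compounds go, whether the change to 1-hydroxy-1-methylethyl shifts activity on the core of compound 3, as it did on the core of compound 1, stays open.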